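Taking the chloro off compound 3

A few compounds are considered here, and "the series" means these few. Any claim that something is new, unique, unknown or untested is made for them only; others in the source may bear on it.

compound 1 `O=c1c(Cl)c(COc2cccc(OCC3CCOCC3)c2)[nH]c2ccccc12` gives 12 nM
compound 2 `CC(C)c1c(COc2cccc(OCC3CCOCC3)c2)[nH]c2ccccc2c1=O` gives 54 nM
compound 3 `Cc1c(COc2cccc(OCC3CCOCC3)c2)[nH]c2ccc(Cl)cc2c1=O` gives 5 nM

These values come from a functional assay on HUVEC cells (Homo sapiens) for inhibition, using NADPH, with a stated time of 2 h (a lower number here means a stronger inhibitor, a higher number a weaker inhibitor), and compound 3 has the lowest number of the three. Compound 4 `Cc1c(COc2cccc(OCC3CCOCC3)c2)[nH]c2ccccc2c1=O` differs from compound 3 by one change: hydrogen in place of chloro on an aromatic carbon. For the measured compounds named here, the only measured step, a 4.5-fold higher number from compound 1 to compound 2 (0.65 log units; beyond the scatter), is a different swap at a different carbon, so it shows only that a single swap can matter. Closer evidence is weak: compound 1 at 12 nM and compound 2 at 54 nM also carry hydrogen on that carbon, but both differ from compound 4 elsewhere. A modest rise in this assay is therefore expected, an estimated 3.0-fold higher number from compound 3 to compound 4 (0.48 log units; beyond the scatter) in all. The estimate for compound 4 is 15 nM, with an expected range from 6 nM to 40 nM.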

Compound 4, half-maximal inhibitory concentration: 8.9 nM
Compound 4: middle estimate off by 1.7-fold (0.23 log units), on the high side; the measured number falls inside the stated range.
By their numbers in this assay, from the lowest: compounds 3, 4 and 1 (each within the scatter of the next, the first and the last beyond it); then compound 2.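

Within this assay, hydrogen in place of chloro on this aromatic carbon gives a 1.8-fold higher number from compound 3 to compound 4 (0.25 log units; within the scatter), so this chloro has no effect that can be told from the scatter. At the other carbon, methyl in place of isopropyl gives a 6.1-fold lower number from compound 2 to compound 4 (0.78 log units; beyond the scatter), whereas methyl in place of chloro gives a 1.3-fold lower number from compound 1 to compound 4 (0.13 log units; within the scatter), so only the isopropyl step stands out from the scatter. Nothing available explains either result. Going by these compounds, whether a fluoro or methoxy group in place of this chloro, or an ethyl group or carboxylic acid in place of the methyl, would keep numbers this low remains open.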